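Hydroxy for methoxy on a cyanomethyl-pyrazole series

The source may hold more compounds than are shown below. What is called first, only, known or untested is meant among the compounds shown, and "the series" means these compounds.

Of the compounds shown here, three of a shared core have been tested in a functional assay on SNB-19 cells (Homo sapiens) for cytotoxicity, read by sulforhodamine B assay, with a stated time of 48 h, tested at 100 nM; on this read-out lower numbers stand for a stronger effect and higher numbers for a weaker effect at the one concentration tested. Compound 1 `COc1cc(C)cc(-c2nn(CC#N)cc2-c2ccc(-c3cccc(C(C)=O)c3)nc2)c1` gives 99%, compound 2 `Cc1cc(O)cc(-c2nn(CC#N)cc2-c2ccnc(-c3ccc(Oc4ccccc4)cc3)c2)c1` gives 94%, and compound 3 `COc1cc(C)cc(-c2nn(CC#N)cc2-c2ccnc(-c3ccc(N(C)C)cc3)c2)c1` gives 35%. Compound 3 therefore stands lowest of the three numbers in this assay, and its distance to both compound 2 and compound 1 lies beyond the usual scatter, so it is the one with the strongest effect among the three.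

The next compound, compound 4 `Cc1cc(O)cc(-c2nn(CC#N)cc2-c2ccnc(-c3ccc(N(C)C)cc3)c2)c1`, differs from compound 3 in one place: hydrogen in place of methyl on an oxygen on an aromatic ring. Within the data shown here, no pair among the measured compounds shows this change on its own; compound 2 carries the hydroxy and compound 1 the methoxy, but they differ from each other elsewhere as well, so their values speak only for themselves.

Among the measured compounds shown here, with no direct precedent, the account expects a step of a number 10 percentage points higher from compound 3 to compound 4 (within the scatter) that stays within or only slightly beyond the scatter, with the larger risk on the side of a weaker effect. Compound 4 is accordingly estimated at 45%, within a range from 20% to 85%.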

Compound 4, a percentage reported as activity, at one concentration (the size of the read-out at that concentration, not a potency): 93%
Beside the measured number, compound 4's estimate is 48 percentage points below it, outside the stated range (above it).
By their numbers in this assay, from the lowest: compound 3; then compounds 4, 2 and 1 (each within the scatter of the next).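

In this assay, hydrogen in place of methyl on an oxygen on an aromatic ring, the change from methoxy to hydroxy, gives a number 58 percentage points higher from compound 3 to compound 4 (beyond the scatter) as its one difference, so the effect seen with compound 3 depends on that methyl, with dimethylamino kept in place. Among these compounds, with the hydroxy kept, dimethylamino in place of phenoxy on an aromatic carbon gives a number 1 percentage points lower from compound 2 to compound 4 (within the scatter) and so does not bring the effect back in this pair; the earlier compounds could show neither point, as none of them differed in one place.

On these data alone, whether a longer chain such as ethyl on that oxygen, or an amine in place of the methoxy, would keep the effect stays open. Nothing available explains why this small change has so large a result.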